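Trimming the sulfonyl substituent down to a plain amino

This account rests on a few compounds, and the source may have more. Where it says the series, first, only, none or still open, it means among the compounds named here.

In a physicochemical assay for solubility, read by HPLC, using the shake flask method, measured as kinetic solubility, with a stated time of 20 h, at pH 6.5, tested at 200 uM (a lower number here means a less soluble compound, a higher number a more soluble compound), compound 1 (`C[C@@H](CO)NS(=O)(=O)c1cccc(-c2ccc3nccc(-c4ccncc4)c3n2)c1`) gives 50000 nM and compound 2 (`O=S(=O)(c1cccc(-c2ccc3nccc(-c4ccncc4)c3n2)c1)N1CCC(O)CC1`) gives 10000 nM as the lower of the two numbers. Among the measured compounds shown here, the only measured step is a 5.0-fold lower number from compound 1 to compound 2 (0.70 log units; beyond the scatter) and, modest though beyond the scatter, it comes with 4-hydroxypiperidin-1-yl in place of (1-(hydroxymethyl)ethyl)amino on a sulfonyl sulfur.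

Compound 3 (`NS(=O)(=O)c1cccc(-c2ccc3nccc(-c4ccncc4)c3n2)c1`) has not yet been measured and carries a further change at that same place, with amino in place of 4-hydroxypiperidin-1-yl on a sulfonyl sulfur. For the measured compounds named here, the earlier step is the one guide to size, since it touches the same sulfur. Going by the values given here, no measured compound carries the amino group, however, so that step does not settle the direction. In this assay no step beyond the scatter is therefore expected, and the estimated change (a 1.3-fold lower number from compound 2 to compound 3 (0.10 log units; within the scatter)) is held with wide uncertainty on both sides. For compound 3 the estimated value is 8000 nM (expected range 2000 nM to 30000 nM).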

Compound 3, solubility: < 5000 nM
Compound 3 was reported as a limit; the forecaster's own chance of this, stated with the estimate: 5%; middle value at least 1.6-fold (0.20 log units) from the limit.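

In this assay compound 3 is reported only as a limit of the assay, not as a number: the limit of < 5000 nM in this assay, at which 1 of the 3 values shown sits.

Placing amino on the sulfonyl sulfur, the result is an at least 2.0-fold lower number from compound 2 to compound 3 (0.30 log units; that floor lies within the scatter), so this change is known only as a floor and is not shown to go beyond the scatter on its own. The comparison with the (1-(hydroxymethyl)ethyl)amino compound is firmer: with hydrogen in place of 1-(hydroxymethyl)ethyl on a sulfonamide nitrogen, the result is an at least 10-fold lower number from compound 1 to compound 3 (1.00 log units; beyond the scatter). The earlier compounds shown here showed only that one substituted sulfonamide could differ from another, whereas this step shows that the plain sulfamoyl end of the series gives a lower number than compound 1 by more than the scatter.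

As far as these compounds go, how far compound 3 lies under its limit stays unknown, and with it the true size of both steps. Also open, from the compounds shown here alone, is where a piperazine or a longer chain ending in a carboxylic acid on the same sulfonyl sulfur would fall relative to compound 1 and compound 2.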